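The source may report more compounds than this note shows. Statements on the series, on what has been measured and on what is new or still open speak of the compounds shown alone.

In a functional assay on BXPC-3 cells (Homo sapiens) for antiproliferative activity, read by MTT assay, with a stated time of 24 h (on this read-out higher numbers stand for weaker inhibition and lower numbers for stronger inhibition), compound 1 (`CCN(CC)CCNC(=O)c1ccc(C(CC)(CC)c2ccc(OCS(=O)(=O)c3ccccc3)c(C)c2)n1CC`), with 2-(diethylamino)ethyl on the amide-type nitrogen, gives 6270 nM. Compound 2 (`CCn1c(C(=O)N[C@H](CO)CCO)ccc1C(CC)(CC)c1ccc(OCS(=O)(=O)c2ccccc2)c(C)c1`) gives 15900 nM, the higher of the two numbers and thus the weaker inhibition. Compound 3 (`CCn1c(C(=O)NC2(C(=O)O)CC2)ccc1C(CC)(CC)c1ccc(OCS(=O)(=O)c2ccccc2)c(C)c1`) keeps the shared core of compound 2 and changes the group on that same nitrogen: 1-carboxycyclopropyl in place of 3-hydroxy-1-(hydroxymethyl)propyl on an amide-type nitrogen. Here 1-carboxycyclopropyl stands in place of 3-hydroxy-1-(hydroxymethyl)propyl. Within the data shown here, no measured compound carries the entering group, so only one measured step bears on this change: a 2.5-fold higher number from compound 1 to compound 2 (0.40 log units; beyond the scatter). Among the measured compounds shown here, that step is modest, and it shows only that exchanging the group at this nitrogen can shift the number in this assay. It does not fix a direction for the new exchange. A step no larger than that modest one is therefore expected, with a tentative lean towards a higher number. The expected step is a 1.5-fold higher number from compound 2 to compound 3 (0.18 log units; within the scatter), which remains an uncertain estimate. For compound 3, the estimated value is 24000 nM, with an expected range from 9000 nM to 60000 nM.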

Compound 3, half-maximal inhibitory concentration: > 50000 nM
Compound 3 gave a limit, no number (the forecaster's own chance of this, stated with the estimate: 15%); middle value at least 2.0-fold (0.31 log units) away from the limit.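

In this assay compound 3 gives > 50000 nM, which is a limit of the assay and not a number. Among these compounds, the one earlier step showed only that the number can shift at this nitrogen, whereas this exchange, with 1-carboxycyclopropyl in place of 3-hydroxy-1-(hydroxymethyl)propyl, gives an at least 3.1-fold higher number from compound 2 to compound 3 (0.49 log units; beyond the scatter), although both groups count the same number of heavy atoms. Set against 2-(diethylamino)ethyl, the same group gives an at least 7.9-fold higher number from compound 1 to compound 3 (0.90 log units; beyond the scatter), so among these three compounds, 2-(diethylamino)ethyl carries the lowest number, 3-hydroxy-1-(hydroxymethyl)propyl the middle one and 1-carboxycyclopropyl the limit.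

Going by these compounds, the full size of both new steps stays open, since only a limit stands at their far end. The compounds shown also do not separate the carboxylic acid from the three-membered ring within the entering group: an open-chain carboxylic acid, or a cyclopropyl group without the acid, on the same amide-type nitrogen would be needed to tell which part goes with the higher number.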